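A few compounds are considered here, and "the series" means these few. Any claim that something is new, unique, unknown or untested is made for them only; others in the source may bear on it.

Two compounds of the series are in hand. Compound 1 `Nc1ccccc1NC(=O)c1ccc(CSC(=S)N2CCN(Cc3ccccn3)CC2)cc1` gives 20.7% in a functional assay on A-375 cells (Homo sapiens) for antiproliferative activity, read by CCK-8 assay, with a stated time of 72 h, tested at 2 uM (on this read-out lower numbers stand for a weaker effect and higher numbers for a stronger effect at the one concentration tested), and compound 2 `Nc1ccccc1NC(=O)c1ccc(CSC(=S)N2CCN(c3ccccc3)CC2)cc1` gives 27.5%. Compound 2 holds the higher of the two numbers, the step of a number 6.8 percentage points higher from compound 1 to compound 2 (within the scatter) lying within the scatter, so no order between them is claimed. Compound 3 `COc1ccc(N2CCN(C(=S)SCc3ccc(C(=O)Nc4ccccc4N)cc3)CC2)cc1` differs from compound 2 by methoxy in place of hydrogen on an aromatic carbon. Among the measured compounds shown here, no measured step bears on this change; the only step in hand concerns the group on the amine nitrogen. A change within the scatter, a number 2.5 percentage points higher from compound 2 to compound 3 (within the scatter), is therefore expected. Compound 3 is estimated at 30%, in the range 12% to 48%.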

Compound 3, a percentage reported as inhibition, at one concentration (the size of the read-out at that concentration, not a potency): 28.1%
Compound 3: middle estimate off by 1.9 percentage points, on the high side; measured number inside the range.
By their numbers in this assay, from the lowest: compounds 1, 2 and 3 (each within the scatter of the next).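

In this assay, methoxy in place of hydrogen, para to a large group, gives a number 0.6 percentage points higher from compound 2 to compound 3 (within the scatter) and so does not separate the two groups at this position. The larger change on the amine nitrogen, 4-methoxyphenyl in place of (pyridin-2-yl)methyl, gives a number 7.4 percentage points higher from compound 1 to compound 3 (within the scatter) and also stays unresolved. No measurement in hand explains either step.

Open, on these data alone, is whether an amine or a carboxylic acid at this position, or a longer chain in place of methoxy, would give a step beyond the scatter.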